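From Compound 3 to Compound 4: A Growth Inhibition Step

The source may report more compounds than this note shows. Statements on the series, on what has been measured and on what is new or still open speak of the compounds shown alone.

Values in a functional assay on MDA-MB-231 cells (Homo sapiens) for inhibition, read by sulforhodamine B assay, with a stated time of 72 h; a higher number here means a weaker inhibitor of growth, a lower number a stronger inhibitor of growth:
Compound 1 `NNC(=O)CCc1ccncc1-c1ccc2ccccc2c1`: > 10000 nM (a limit of the assay)
Compound 2 `O=C(CCc1ccncc1-c1ccc2ccccc2c1)N1CCOCC1`: > 10000 nM (a limit of the assay)
Compound 3 `CN(C)C(=O)/C=C/c1ccncc1-c1ccc2ccccc2c1`: 7990 nM

Going by the values given here, compound 3 gives the only true number here, 7990 nM. The other two entries stand at the limit of > 10000 nM in this assay, at which 2 of the 3 values shown sit.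

The next compound is compound 4 `O=C(O)CCc1ccncc1-c1ccc2ccccc2c1`. The change is 2-carboxyethyl in place of 2-(dimethylcarbamoyl)ethenyl on an aromatic carbon, with 2-carboxyethyl in place of 2-(dimethylcarbamoyl)ethenyl on an aromatic carbon, opposite the ring nitrogen.

The nearest measured evidence is an at least 1.2-fold lower number from compound 1 to compound 3 (0.09 log units; that floor lies within the scatter), which involves the same 2-(dimethylcarbamoyl)ethenyl group. The other step, a step that the two limits leave unreadable from compound 1 to compound 2, gives no usable size. Among the compounds with values here, no measured compound carries the 2-carboxyethyl group. Compound 4 shares its two-carbon ethyl link with compound 1, whose > 10000 nM is a limit, so a small move to a higher number in this assay is expected. The expected change is a 1.5-fold higher number from compound 3 to compound 4 (0.18 log units; within the scatter). For compound 4, the estimated value is 12000 nM, with an expected range of 7000 nM to 20000 nM.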

Compound 4, concentration for 50% growth inhibition: > 10000 nM
Compound 4 gave a limit, no number (the forecaster's own chance of this, stated with the estimate: 75%); the middle value is on the limit's open side.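

In this assay, placing 2-carboxyethyl in place of 2-(dimethylcarbamoyl)ethenyl, opposite the ring nitrogen, gives an at least 1.2-fold higher number from compound 3 to compound 4 (0.09 log units; that floor lies within the scatter), so only a floor for this step is known and its true size is not. The steps to compound 4 from compound 1 and from compound 2 cannot be read, as both ends of each are limits. What is new is that a third end group on the saturated two-carbon link, the carboxylic acid of compound 4, also stops at the same limit: the limit of > 10000 nM in this assay, at which 3 of the 4 values shown sit.

The compounds shown leave open whether the ethenyl link or the dimethylamide end goes with the measured value of compound 3, 7990 nM. On these data alone, a 2-carboxyethenyl group or a dimethylamide on the ethyl link would separate the two, and a longer chain ending in an amine remains unexplored here.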